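The source may report more compounds than this note shows. Statements on the series, on what has been measured and on what is new or still open speak of the compounds shown alone.

Among the compounds with values here, in a functional assay on SMMC-7721 cells (Homo sapiens) for cytotoxicity, read by MTT assay, with a stated time of 4 days (a lower number here means a stronger inhibitor, a higher number a weaker inhibitor), compound 1 `C=C1C(=O)[C@]23C[C@@]1(O)CC[C@H]2c1ccc(OS(=O)(=O)c2ccc(C)cc2)c(C)c1[C@@H]3Cn1cc(-c2ccc(Br)cc2)nn1` gives 4320 nM, the one actual number among the three values recorded so far. Compound 2 `Cc1c(O)ccc2c1[C@H](Cn1cc(-c3ccc(Cl)cc3)nn1)[C@@]13CC(=O)[C@@](C)(CC[C@@H]21)C3` sits at > 20000 nM, which is a limit of the assay rather than a measured number. Compound 3 `Cc1ccc(S(=O)(=O)Oc2ccc3c(c2C)[C@H](Cn2cc(-c4ccccn4)nn2)[C@@]24CC(=O)[C@@](C)(CC[C@@H]32)C4)cc1` likewise sits at > 20000 nM, again a limit and not a number. Compound 4 `C=C1C(=O)[C@]23C[C@@]1(O)CC[C@H]2c1ccc(OS(=O)(=O)c2ccc(C)cc2)c(C)c1[C@@H]3Cn1cc(-c2ccc(C)cc2)nn1` has not yet been measured; it differs from compound 1 by methyl in place of bromo on an aromatic carbon. Within the data shown here, no pair of measured compounds differing in a single place is available to guide the size of this step in this assay. The step from compound 1 to compound 4 is expected to be a 1.2-fold higher number from compound 1 to compound 4 (0.06 log units; within the scatter), no more than the usual scatter. Compound 4 is therefore expected to give about 5000 nM, between 2000 nM and 12000 nM.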

Compound 4, half-maximal inhibitory concentration: 4410 nM
For compound 4 the middle estimate is 1.1-fold (0.05 log units) above the measured one, within the range that was stated.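

In this assay, methyl in place of bromo on the 4-bromophenyl group gives a 1.0-fold higher number from compound 1 to compound 4 (0.01 log units; within the scatter). Within the data shown here, this is the first pair of measured compounds that differ in one place, and at this aromatic carbon, para to a large group, it does not tell the two groups apart. One pair cannot show whether the position tolerates change in general.

Going by these compounds, whether an amine or a carboxylic acid here would move the number stays open. A loss of activity could be followed only so far, since the scale ends in a limit: the limit of > 20000 nM in this assay, at which 2 of the 4 values shown sit.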